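A few compounds are considered here, and "the series" means these few. Any claim that something is new, unique, unknown or untested is made for them only; others in the source may bear on it.

Compound 1 `Nc1cccc(-c2cccc(NC(=O)C(Cl)Cl)c2)c1`: 50000 nM
Compound 2 `COc1cccc(-c2cccc(NC(=O)C(Cl)Cl)c2)c1`: 4310 nM

In a functional assay on A549 cells (Homo sapiens) for cytotoxicity, read by MTT assay, with a stated time of 68 h (a lower number here means a stronger inhibitor, a higher number a weaker inhibitor), compound 2, at 4310 nM, holds the lower of the two numbers. Compound 3 `COc1cccc(-c2cc(NC(=O)C(Cl)Cl)cc(-c3cccc(OC)c3)c2)c1` keeps all of compound 2 and alters one place: 3-methoxyphenyl in place of hydrogen on an aromatic carbon. Within the data shown here, only one measured step exists, a 12-fold lower number from compound 1 to compound 2 (1.06 log units; beyond the scatter). It is large, but it swapped amino for methoxy, which is a different change, and it gives no size for adding a 3-methoxyphenyl group. Only a small drop is therefore expected, with its direction uncertain. The expected change is a 1.7-fold lower number from compound 2 to compound 3 (0.24 log units; within the scatter). The estimated value for compound 3 is 2500 nM, with an expected range of 700 nM to 12000 nM.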

Compound 3, half-maximal inhibitory concentration: 9400 nM
Compound 3: the middle estimate sits 3.8-fold (0.58 log units) below what was measured; measured number inside the range.
By their numbers in this assay, from the lowest: compound 2; then compound 3; then compound 1.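

Putting a 3-methoxyphenyl group on this aromatic carbon, where compound 2 has only hydrogen, gives a 2.2-fold higher number from compound 2 to compound 3 (0.34 log units; beyond the scatter) in this assay and so weakens the compound modestly. Among these compounds, this is the first measured effect of a change at this position, and enlarging the molecule here brings no gain in this pair. Nothing measured here explains the loss.

On these data alone, whether the loss comes from the added ring or from its methoxy remains open, and a plain phenyl group would help separate the two. A smaller group such as methyl at this place also remains untested among the compounds shown.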